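Chlorine Placement on the Amide Phenyl Group

A few compounds are considered here, and "the series" means these few. Any claim that something is new, unique, unknown or untested is made for them only; others in the source may bear on it.

Two compounds set the frame. Compound 1 `Cn1cc(-c2cnc(N)c(Oc3ccc(C(=O)Nc4ccccc4Cl)cc3)n2)cn1` carries a 2-chlorophenyl on the amide-type nitrogen, and in a functional assay on HeLa cells (Homo sapiens) for inhibition, read by MTT assay, with a stated time of 72 h (a lower number here means a stronger inhibitor, a higher number a weaker inhibitor), compound 1 gives 73000 nM. Compound 2 `Cn1cc(-c2cnc(N)c(Oc3ccc(C(=O)Nc4ccc(Cl)cc4)cc3)n2)cn1` carries a 4-chlorophenyl in that place, and in this assay compound 2 gives 3440 nM; the change amounts to a 21-fold lower number from compound 1 to compound 2 (1.33 log units; beyond the scatter). On these two numbers compound 2 stands as the lower of the pair, well beyond the scatter from compound 1.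

Compound 3 `Cn1cc(-c2cnc(N)c(Oc3ccc(C(=O)Nc4cccc(Cl)c4)cc3)n2)cn1` differs from compound 2 in a single place: 3-chlorophenyl in place of 4-chlorophenyl on an amide-type nitrogen. Within the data shown here, only one measured step bears on this region, the step between compound 1 and compound 2, and it was large, yet it concerned the 2-chlorophenyl rather than the 3-chlorophenyl. It shows that where the chlorine sits can matter greatly, without saying where the 3-chlorophenyl will land. Some weakening relative to compound 2 is expected, but not a full return to the level of compound 1: compound 3 is estimated at 9000 nM in this assay, with a range from 2500 nM to 40000 nM. The expected step is a 2.6-fold higher number from compound 2 to compound 3 (0.42 log units; beyond the scatter), placed between the two measured anchors.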

Compound 3, half-maximal inhibitory concentration: 4460 nM
Compound 3: the middle estimate sits 2.0-fold (0.30 log units) above what was measured; low and high end bracket the measured number.
By their numbers in this assay, from the lowest: compounds 2 and 3 (each within the scatter of the next); then compound 1.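

In this assay, 3-chlorophenyl in place of 4-chlorophenyl on the amide-type nitrogen gives a 1.3-fold higher number from compound 2 to compound 3 (0.11 log units; within the scatter) and leaves the two compounds indistinguishable, so this change has no measurable effect on the number. The other new comparison, a 16-fold lower number from compound 1 to compound 3 (1.21 log units; beyond the scatter), lies beyond the scatter, as does a 21-fold lower number from compound 1 to compound 2 (1.33 log units; beyond the scatter), which means that compound 1 stands apart from both other compounds and that the large step seen earlier was not specific to the 4-chlorophenyl. Within this set, then, only the 2-chlorophenyl separates from the others, while the data offer no measured explanation for that separation.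

The compounds shown leave open whether this reading would hold if the chlorine gave way to fluorine, a methyl group, a methoxy group or an amine, and whether a plain phenyl with no added group would match compound 2 and compound 3 or fall closer to compound 1. They also leave open what a saturated ring such as cyclohexyl, or a short alkyl chain, would do on the amide-type nitrogen in place of the chlorophenyl.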